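This account rests on a few compounds, and the source may have more. Where it says the series, first, only, none or still open, it means among the compounds named here.

Measured in an ADME assay on L02 cells (Homo sapiens) for inhibition, read by CCK-8 assay, with a stated time of 48 h; a lower number here means a stronger inhibitor of growth, a higher number a weaker inhibitor of growth:
- compound 1 `Cc1ccccc1Nc1nc(Nc2ccc(N3CCN(C)CC3)cc2)ncc1Cl`: 6510 nM
- compound 2 `Cc1ccccc1Nc1nc(Nc2ccc(N3CCN(C(=O)OC(C)(C)C)CC3)cc2)ncc1Cl`: 1750 nM
- compound 3 `Cc1ccc(CNc2nc(Nc3ccc(N4CCN(C)CC4)cn3)ncc2Cl)cc1`: > 100000 nM

Compound 3 stands at > 100000 nM, which is a limit of the assay and not a number.

Compound 4 `COc1ccccc1CNc1nc(Nc2ccc(N3CCN(C)CC3)cn2)ncc1Cl` differs from compound 3 at one place, on a saturated chain carbon bound to a nitrogen on an aromatic ring: 2-methoxyphenyl in place of 4-methylphenyl on a saturated chain carbon bound to a nitrogen on an aromatic ring. Thus 2-methoxyphenyl replaces 4-methylphenyl, and the 4-methylbenzyl group becomes 2-methoxybenzyl.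

For the measured compounds named here, no measured step touches that place. The only one available lies elsewhere, with tert-butoxycarbonyl in place of methyl on an amine nitrogen in a ring: a 3.7-fold lower number from compound 1 to compound 2 (0.57 log units; beyond the scatter). That modest step serves only as a rough gauge of how far one change has moved the number in this assay. Since compound 3 has no exact value, the size of the coming step cannot be fixed. At most a modest move toward a lower number is expected, and no move beyond the scatter is just as possible.

The expected change is an at least 1.2-fold lower number from compound 3 to compound 4 (0.09 log units; that floor lies within the scatter). Compound 4 is estimated at 80000 nM, with an expected range from 20000 nM to 150000 nM. The assay may well report only a limit again.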

Compound 4, concentration for 50% growth inhibition: 25500 nM
Compound 4: middle estimate off by 3.1-fold (0.50 log units), on the high side; measured number inside the range.
By their numbers in this assay, from the lowest: compound 2; then compound 1; then compound 4. At a limit, above all of these: compound 3.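

In this assay, for the compounds shown here, 2-methoxyphenyl in place of 4-methylphenyl on a saturated chain carbon bound to a nitrogen on an aromatic ring gives an at least 3.9-fold lower number from compound 3 to compound 4 (0.59 log units; beyond the scatter) and so provides the first reading at this place. The earlier step concerned only an amine nitrogen in a ring, whereas this one shows that the group on the chain carbon can also move the number beyond the scatter, toward stronger inhibition of growth. The size of the step remains a floor and not a measured distance because compound 3 gives a limit and not a number: the limit of > 100000 nM in this assay, at which 1 of the 4 values shown sits.

The compounds shown do not separate the arrival of the methoxy group from the loss of the methyl group, and they leave open how a plain phenyl, an amine or a longer chain would read at this place. They also leave open whether tert-butoxycarbonyl in place of methyl on the ring amine nitrogen would move compound 4 as it moved the number of compound 1.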